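From (4-Fluorophenyl)sulfamoyl to (4-Bromophenyl)sulfonyl

The compounds below may be only part of what the source reports. "The series", "measured", "known", "first", "only" and "open" are said of these compounds alone.

Of the compounds shown here, three that share one core have been tested in a functional assay on DU-145 cells (Homo sapiens) for inhibition, read by trypan blue exclusion, with a stated time of 72 h; on this read-out lower numbers stand for stronger inhibition and higher numbers for weaker inhibition. Compound 1 (`Cn1c(=O)c(C(=O)Nc2ccc(F)cc2F)cc2cnc(Nc3ccc4[nH]ccc4c3)nc21`) gives 5000 nM. Compound 2 (`COc1ccc(S(=O)(=O)c2cc3cnc(Nc4ccc5[nH]ccc5c4)nc3n(C)c2=O)cc1`) gives 500 nM. Compound 3 (`Cn1c(=O)c(S(=O)(=O)Nc2ccc(F)cc2)cc2cnc(Nc3ccc4[nH]ccc4c3)nc21`) gives 5000 nM, level with compound 1 at the digits shown, and together they hold the highest of the three numbers.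

Compound 4 (`Cn1c(=O)c(S(=O)(=O)c2ccc(Br)cc2)cc2cnc(Nc3ccc4[nH]ccc4c3)nc21`) has not yet been measured. It carries 4-bromophenyl in place of the (4-fluorophenyl)amino of compound 3 on a sulfonyl sulfur: 4-bromophenyl in place of (4-fluorophenyl)amino on a sulfonyl sulfur.

The closest guide is a 10-fold higher number from compound 2 to compound 3 (1.00 log units; beyond the scatter), where (4-fluorophenyl)amino replaced 4-methoxyphenyl on that same sulfonyl sulfur. The change now at hand runs the opposite way, again leaving a carbon ring attached directly to the sulfur. The other two steps agree with this picture: a 10-fold lower number from compound 1 to compound 2 (1.00 log units; beyond the scatter), but no change at the digits printed from compound 1 to compound 3 (within the scatter). Among the compounds with values here, still, compound 2 is the only measured compound of this type, and nothing yet compares 4-bromophenyl with 4-methoxyphenyl directly.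

A drop of similar size is therefore expected in this assay, and the expected step is an 8.3-fold lower number from compound 3 to compound 4 (0.92 log units; beyond the scatter). Compound 4 is estimated at 600 nM, with an expected range from 150 nM to 2500 nM.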

Compound 4, half-maximal inhibitory concentration: 5000 nM
Compound 4: the middle estimate sits 8.3-fold (0.92 log units) below what was measured; the measured number lies above the stated range.
By their numbers in this assay, from the lowest: compound 2; then compounds 1, 3 and 4 (each within the scatter of the next).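

The sulfonyl sulfur carrying a carbon ring directly is not enough on its own to lower the number in this assay: the swap of (4-fluorophenyl)amino for 4-bromophenyl gives no change at the digits printed from compound 3 to compound 4 (within the scatter). Within the data shown here, the first direct comparison of two groups on that ring shows where the difference lies, since bromo in place of methoxy on an aromatic carbon gives a 10-fold higher number from compound 2 to compound 4 (1.00 log units; beyond the scatter), so in this pair the outcome turns on that single ring group rather than on the sulfonyl link. The step of no change at the digits printed from compound 1 to compound 4 (within the scatter) adds that the (2,4-difluorophenyl)carbamoyl, (4-fluorophenyl)sulfamoyl and (4-bromophenyl)sulfonyl groups all read alike here, which leaves compound 2, with its 4-methoxyphenyl group, as the only one of the four set apart by a step beyond the scatter.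

Nothing measured here accounts for the gap between methoxy and bromo. As far as these compounds go, it also remains open whether the lower number is particular to methoxy, or whether an ethoxy, a hydroxy or a dimethylamino group on the same ring would give it too.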